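Solubility of four compounds sharing one core

The compounds below may be only part of what the source reports. "The series", "measured", "known", "first", "only" and "open" are said of these compounds alone.

Measured so far:
compound 1 `CC[C@H]1[C@@H](N)CN1c1cc2c(cc1F)c(=O)c(C(=O)O)cn2C1CC1`: 42.2 ug/mL
compound 2 `CC[C@H]1[C@@H](N)CN1c1c(F)cc2c(=O)c(C(=O)O)cn(C3CC3)c2c1F`: 55.9 ug/mL
compound 3 `CNC1CN(c2c(F)cc3c(=O)c(C(=O)O)cn(C4CC4)c3c2F)C1`: 1.7 ug/mL

In a physicochemical assay for solubility, at pH 7.4 (a lower number here means a less soluble compound, a higher number a more soluble compound), compound 1 gives 42.2 ug/mL, the second highest of the three numbers. Its nearest neighbour is compound 2, and the step of a 1.3-fold higher number from compound 1 to compound 2 (0.12 log units; within the scatter) lies within the scatter. Compound 3 stands far below both.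

Compound 4 `C[C@@H]1[C@@H](N(C)C)CN1c1cc2c(cc1F)c(=O)c(C(=O)O)cn2C1CC1` differs from compound 1 in one place: a group of 8 heavy atoms (6 carbon, 2 nitrogen; one four-membered non-aromatic ring with 1 hetero atom) in place of a group of 7 heavy atoms (5 carbon, 2 nitrogen; one four-membered non-aromatic ring with 1 hetero atom), on an aromatic carbon. The group that leaves carries one hydrogen-bond donor, the group that enters none. Among the measured compounds shown here, only the step of a 33-fold lower number from compound 2 to compound 3 (1.52 log units; beyond the scatter) bears on such an exchange of one four-membered ring group for another, and it was large and downward, though that change also removed one carbon. Compound 4 is therefore expected to give a lower number, a 2.1-fold lower number from compound 1 to compound 4 (0.32 log units; beyond the scatter), with compound 4 estimated at 20 ug/mL within a range of 5 ug/mL to 80 ug/mL.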

Compound 4, solubility: 96.3 ug/mL
Estimate against measurement, compound 4: 4.8-fold (0.68 log units) below; the whole stated range lies below it.
By their numbers in this assay, from the lowest: compound 3; then compounds 1, 2 and 4 (each within the scatter of the next, the first and the last beyond it).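

In this assay, among the compounds shown here, the exchange of one four-membered ring group for another on this aromatic carbon now runs upward, with a 2.3-fold higher number from compound 1 to compound 4 (0.36 log units; beyond the scatter) as the step, whereas a 33-fold lower number from compound 2 to compound 3 (1.52 log units; beyond the scatter) is the step of the one earlier such exchange, which ran downward. The direction of such an exchange is therefore not fixed among these compounds, and the entering group of compound 4 holds 0 hydrogen-bond donors. Nothing measured here accounts for the upward step.

Still open, on these data alone, is how a hydroxyl group or a longer chain on the four-membered ring would behave at this position on the shared core.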